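The source may hold more compounds than are shown below. What is called first, only, known or untested is meant among the compounds shown, and "the series" means these compounds.

Among the compounds with values here, in a functional assay (Homo sapiens) for inhibition (a higher number here means a weaker inhibitor, a lower number a stronger inhibitor), compound 1 `O=C(O)/C=C/c1ccc(-c2ccc(O)cc2)cc1` gives 156000 nM, and compound 2 `O=C(O)/C=C/c1ccc(-c2ccc(O)c(CC3CCCCC3)c2)cc1` gives 2300 nM, the lower of the two numbers so far. Compound 3 `CC(C)(C)c1cc(-c2ccc(/C=C/C(=O)O)cc2)ccc1O` carries the change tert-butyl in place of cyclohexylmethyl on an aromatic carbon, ortho to a hydroxy group. Within the data shown here, the only measured step bearing on this is a 68-fold lower number from compound 1 to compound 2 (1.83 log units; beyond the scatter), large and beyond the scatter, for cyclohexylmethyl in place of hydrogen on that carbon. With a carbon-only group retained there, part of that gain is expected to remain, alongside a moderately higher number in this assay. The estimated move is a 3.5-fold higher number from compound 2 to compound 3 (0.54 log units; beyond the scatter). For compound 3 the expected value is 8000 nM, within an estimated range of 2500 nM to 30000 nM.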

Compound 3, half-maximal inhibitory concentration: 30000 nM
The estimate for compound 3 lay 3.8-fold (0.57 log units) below the measured number; measured number inside the range.
By their numbers in this assay, from the lowest: compound 2; then compound 3; then compound 1.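

Not every carbon-only group on this aromatic carbon, ortho to a hydroxy group, gives the same gain: tert-butyl still leaves a 5.2-fold lower number from compound 1 to compound 3 (0.72 log units; beyond the scatter) and yet the change from cyclohexylmethyl gives a 13-fold higher number from compound 2 to compound 3 (1.12 log units; beyond the scatter) here. Of the two groups, only cyclohexylmethyl carries a six-membered non-aromatic ring. Nothing on hand accounts for the gap between these two groups.

Open, as far as these compounds go, is whether the ring itself or the larger carbon count tracks with the lower number; a directly attached cyclohexyl or a longer open chain such as n-hexyl would separate the two. Also open, from the compounds shown here alone, is how a group carrying an amine would behave at this carbon.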